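Phenyl to 4-methylphenyl on compound 2

The source may hold more compounds than are shown below. What is called first, only, known or untested is meant among the compounds shown, and "the series" means these compounds.

- compound 1 `O=C(/C=C/c1ccc2c(c1)OCCO2)NS(=O)(=O)c1ccc(F)cc1` gives 52.1 ug/mL in this series
- compound 2 `O=C(/C=C/c1ccc2c(c1)OCCCO2)NS(=O)(=O)c1ccccc1` gives 53.9 ug/mL in this series

In a functional assay on MCF7 cells (Homo sapiens) for antiproliferative activity, read by MTT assay, with a stated time of 48 h (on this read-out higher numbers stand for weaker inhibition and lower numbers for stronger inhibition), compound 2 at 53.9 ug/mL and compound 1 at 52.1 ug/mL lie within the scatter of each other, so neither ranks ahead. Compound 3 `Cc1ccc(S(=O)(=O)NC(=O)/C=C/c2ccc3c(c2)OCCCO3)cc1` has methyl in place of hydrogen on an aromatic carbon, para to a large group methyl in place of hydrogen on an aromatic carbon and is otherwise the same as compound 2. Among the compounds with values here, no single-place step has been measured yet, so the expectation rests on this small change alone. In this assay no shift beyond the scatter is expected in either direction, with a 1.1-fold lower number from compound 2 to compound 3 (0.05 log units; within the scatter) as the estimated step. For compound 3 the expected value is 48 ug/mL with an estimated range from 22 ug/mL to 100 ug/mL in this assay.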

Compound 3, half-maximal inhibitory concentration: > 100 ug/mL
Compound 3: only a limit was reported (the forecaster's own chance of this, stated with the estimate: 8%); at least 2.0-fold (0.31 log units) between middle value and limit.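

In this assay compound 3 gives > 100 ug/mL as a limit of the assay and not a number. Within the data shown here, the methyl para to a large group supplies the first single-place step (an at least 1.8-fold higher number from compound 2 to compound 3 (0.26 log units; that floor lies within the scatter)) and brings no stronger inhibition on this read-out. On these data alone, the floor of that step lies within the scatter, so a real loss is not established and the true size of the step remains unknown.

As far as these compounds go, whether a chlorine, a methoxy or an amine at this position would give a number short of the limit stays open. Also open, from the compounds shown here alone, is whether the same methyl step holds on the core of compound 1.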